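Sulfonyl swap on the limit: compound 3 to compound 4

The compounds below may be only part of what the source reports. "The series", "measured", "known", "first", "only" and "open" are said of these compounds alone.

Values in a functional assay on HEK293 cells (Homo sapiens) for cytotoxicity (a lower number here means that less compound is tolerated, a higher number that more compound is tolerated), all of them limits:
- compound 1 `COc1ccc([C@H]2CC(=O)N(c3cccc(O)c3)C2)cc1OC1CCCC1`: > 10000 nM
- compound 2 `COc1ccc([C@H]2CC(=O)N(c3cccc(NS(=O)(=O)c4cccc(Cl)c4)c3)C2)cc1OC1CCCC1`: > 10000 nM
- compound 3 `COc1ccc([C@H]2CC(=O)N(c3cccc(NS(=O)(=O)c4ccc(F)cc4)c3)C2)cc1OC1CCCC1`: > 10000 nM

Compound 3 stands at > 10000 nM, which is a limit and not a number. It shares that position with the rest of the series: the limit of > 10000 nM in this assay, at which 3 of the 3 values shown sit.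

The next change is 4-bromo-5-chlorothiophen-2-yl in place of 4-fluorophenyl on a sulfonyl sulfur, and it gives compound 4 `COc1ccc([C@H]2CC(=O)N(c3cccc(NS(=O)(=O)c4cc(Br)c(Cl)s4)c3)C2)cc1OC1CCCC1`.

The nearest measured change, at the same place, is a step that the two limits leave unreadable from compound 2 to compound 3. The other two, a step that the two limits leave unreadable from compound 1 to compound 2 and a step that the two limits leave unreadable from compound 1 to compound 3, also have no readable size. No size or direction can therefore be carried over to this assay, and no step beyond the scatter is expected, with another limit the likely report.

The expected step is a number no higher from compound 3 to compound 4 (the limit leaves the size open).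

Compound 4 is estimated at 10000 nM, with an expected range of 5000 nM to 20000 nM.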

Compound 4, half-maximal cytotoxic concentration: > 10000 nM
Compound 4 ended at the assay's limit; the forecaster's own chance of this, stated with the estimate: 85%; the middle value lies on the limit itself.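

Compound 4 reads as a limit, as do compound 1, compound 2 and compound 3, so no step among them can be read: the limit of > 10000 nM in this assay, at which 4 of the 4 values shown sit.

The compounds shown leave open how the sulfonyl groups rank in this assay, since none gives a number.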